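The source may hold more compounds than are shown below. What is called first, only, known or untested is meant among the compounds shown, and "the series" means these compounds.

Compound 1 `S=c1[nH]nc(-c2ccccc2Sc2ccccc2)o1` gives 13.1% in a functional assay on the whole organism (strain NMRI) for inhibition, with Mus musculus as the target, in the formalin test, with a stated time of 30 min, at a dose of 30 umol/kg by the intraperitoneal route; on this read-out lower numbers stand for less inhibition and higher numbers for more inhibition at the one dose given (going by the name of the read-out). Compound 2 `O=S(=O)(c1ccccc1)c1ccccc1-c1n[nH]c(=S)o1` gives 41.9%. Compound 3 `Nc1nnc(-c2ccccc2Sc2ccccc2)o1` gives 16.6%.

Compound 3 arises from compound 1 through (a group of 6 heavy atoms (2 carbon, 3 nitrogen, 1 oxygen; one five-membered aromatic ring with 3 hetero atoms) in place of a group of 6 heavy atoms (2 carbon, 2 nitrogen, 1 oxygen, 1 sulfur; one five-membered aromatic ring with 3 hetero atoms), on an aromatic carbon), and in this assay that change produced a number 3.5 percentage points higher from compound 1 to compound 3 (within the scatter). The difference between the cores of compound 1 and compound 2 is not broken down here; compound 2 simply stands highest of the three, beyond the scatter from both others. Compound 4 `Nc1nnc(-c2ccccc2S(=O)(=O)c2ccccc2)o1` has not been measured; it is derived from compound 2 by a group of 6 heavy atoms (2 carbon, 3 nitrogen, 1 oxygen; one five-membered aromatic ring with 3 hetero atoms) in place of a group of 6 heavy atoms (2 carbon, 2 nitrogen, 1 oxygen, 1 sulfur; one five-membered aromatic ring with 3 hetero atoms), on an aromatic carbon, the same kind of change. Because the earlier step was only a number 3.5 percentage points higher from compound 1 to compound 3 (within the scatter), compound 4 is expected to move by about a number 1.1 percentage points higher from compound 2 to compound 4 (within the scatter), and its value in this assay is estimated at 43%, with a range from 26% to 60%.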

Compound 4, a percentage reported as inhibition, in the whole organism at one dose (the size of the read-out at that dose, not a potency): 40.5%
Compound 4: middle estimate off by 2.5 percentage points, on the high side; the measured number falls inside the stated range.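

Replacing the sulfur-containing group with 5-amino-1,3,4-oxadiazol-2-yl gave a number 1.4 percentage points lower from compound 2 to compound 4 (within the scatter) in this assay. Set beside the earlier step, the change shows no difference between the two cores: the same change on two cores in this assay, a number 3.5 percentage points higher (within the scatter) from compound 1 to compound 3 and a number 1.4 percentage points lower (within the scatter) from compound 2 to compound 4, 4.9 percentage points apart, within the scatter of two such steps. This shows only that, in these two pairs at one dose, the change left the number within the scatter on both cores; it does not show that the two groups are interchangeable on other cores or in other read-outs.

On these data alone, whether a carboxylic acid or a longer chain ending in an amine, in place of 5-amino-1,3,4-oxadiazol-2-yl, would give a similar number remains open. As far as these compounds go, how either core behaves at other doses also remains open.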